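Thiosemicarbazone series: growth inhibition on Vero cells

The source may hold more compounds than are shown below. What is called first, only, known or untested is meant among the compounds shown, and "the series" means these compounds.

Measured compounds in an ADME assay on Vero cells (Chlorocebus sabaeus) for inhibition, read by sulforhodamine B assay, with a stated time of 48 h; on this read-out lower numbers stand for stronger inhibition of growth and higher numbers for weaker inhibition of growth:
compound 1 `CC1=CC[C@H](C(C)(C)NC(=S)N/N=C/c2ccc(O)cc2)CC1` gives > 100000 nM, which is a limit of the assay and not a number.
compound 2 `CC1=CC[C@H](C(C)(C)NC(=S)N/N=C/c2ccc(N(C)C)cc2)CC1` gives 75600 nM.

Compound 1 stands at the limit of > 100000 nM in this assay, at which 1 of the 2 values shown sits, so only a limit is known for it. Compound 3 `CC1=CC[C@H](C(C)(C)NC(=S)N/N=C/c2ccccc2Cl)CC1` differs from compound 1 by 2-chlorophenyl in place of 4-hydroxyphenyl on a carbon with a double bond to nitrogen. Going by the values given here, the single measured step, an at least 1.3-fold lower number from compound 1 to compound 2 (0.12 log units; that floor lies within the scatter), lies within the scatter and involves another change of the same group, so no movement beyond the scatter in this assay is expected from this change either. Compound 3 is estimated at 100000 nM (range 40000 nM to 250000 nM), quite possibly reported again as a limit. The expected step is a number no higher from compound 1 to compound 3 (the limit leaves the size open).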

Compound 3, concentration for 50% growth inhibition: 74600 nM
Compound 3: middle estimate off by 1.3-fold (0.13 log units), on the high side; measured number inside the range.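

In this assay, the exchange at the carbon with a double bond to nitrogen gives an at least 1.3-fold lower number from compound 1 to compound 3 (0.12 log units; that floor lies within the scatter) and is the first change shown to a group with 0 hydrogen-bond donors and 0 hydrogen-bond acceptors. With this entering group, as with the dimethylamino change, no movement beyond the scatter can be read. The true size of the step stays open because compound 1 carries a limit and not a number: the limit of > 100000 nM in this assay, at which 1 of the 3 values shown sits.

Going by these compounds, whether a carboxylic acid or a primary amine on the aromatic ring would move the number beyond the scatter stays open. So does the effect of replacing the aromatic ring with a longer alkyl chain.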